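Configuration change in the bicyclic amine of compound 2

The source may report more compounds than this note shows. Statements on the series, on what has been measured and on what is new or still open speak of the compounds shown alone.

Compound 2 `Brc1cncc(OC[C@@H]2C[C@H]3C[C@H]3N2)c1` gives 6.4 nM in an assay on CHO-K1 cells for displacement of a labelled ligand from Neuronal acetylcholine receptor; alpha4/beta2 (Homo sapiens), read by scintillation counting (on this read-out lower numbers stand for stronger inhibition and higher numbers for weaker inhibition), and holds the lowest of the two numbers recorded so far. For the measured compounds named here, its only measured neighbour, compound 1 `C=Cc1nnc(-c2cncc(OC[C@@H]3C[C@H]4C[C@H]4N3)c2)o1`, gives 2660 nM in this assay, and the one measured step, a 420-fold lower number from compound 1 to compound 2 (2.62 log units; beyond the scatter), comes from exchanging a group of 7 heavy atoms, one five-membered aromatic ring with 3 hetero atoms, for a single bromine atom on an aromatic carbon.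

Compound 3 `Brc1cncc(OC[C@@H]2C[C@@H]3C[C@@H]3N2)c1` keeps the bromine and the whole skeleton of compound 2 and differs only as follows: the two compounds have the same atoms and bonds and differ only in configuration as drawn: 2 of 3 stereo elements differ; a stereocentre at a saturated ring carbon is drawn R in compound 2 and S in compound 3; a stereocentre at a saturated ring carbon is drawn R in compound 2 and S in compound 3. Going by the values given here, no measured pair differs by configuration alone, so the step from compound 1 to compound 2 does not bear directly on this change; it only shows that this assay resolves large differences. With two stereocentres inverted the outcome cannot be read from the data, and a weakening is assumed as the more probable case, with wide uncertainty.

The step of a 6.3-fold higher number from compound 2 to compound 3 (0.80 log units; beyond the scatter) is therefore expected to be a rise in the number. For compound 3 a value of 40 nM in this assay is estimated, within 5 nM to 400 nM.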

Compound 3, inhibition constant: 2.9 nM
Compound 3: the middle estimate sits 14-fold (1.14 log units) above what was measured, outside the stated range (below it).
By their numbers in this assay, from the lowest: compound 3; then compound 2; then compound 1.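

Inverting the two ring stereocentres costs nothing in this assay: the step is a 2.2-fold lower number from compound 2 to compound 3 (0.34 log units; beyond the scatter), modest, but printed as beyond the scatter, and in the direction of stronger inhibition. For the compounds shown here, until now the only measured change lay on an aromatic carbon, and that change, a 420-fold lower number from compound 1 to compound 2 (2.62 log units; beyond the scatter), is far larger, so within these three compounds the exchange of the aromatic substituent moves the number much more than the configuration of the ring stereocentres does. The step from compound 2 to compound 3 can be assigned to configuration and to nothing else, because no atom or bond separates the two compounds: the fact that compounds 2 and 3 differ only in the configuration as drawn

Going by these compounds, whether compound 3's configuration keeps its small advantage when the bromine gives way to another group on the same aromatic carbon, such as a chlorine atom or a nitrile, stays open, and so does its effect on the weak five-membered-ring compound 1. Open too, on these data alone, is what the third stereo element contributes, since it is the same in compound 2 and compound 3, and whether the two inverted stereocentres act separately or only together.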